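Removing the phenyl from the pyridine of compound 3

The source may hold more compounds than are shown below. What is called first, only, known or untested is meant among the compounds shown, and "the series" means these compounds.

Going by the values given here, compound 3 `C1=C(c2ccc(-c3ccccc3)nc2)CC2CNCC1C2` stands highest of the three numbers so far in an in vitro assay on SH-SY5Y cells for displacement of a labelled ligand from Neuronal acetylcholine receptor; alpha3/beta4 (Homo sapiens) (a lower number here means a stronger inhibitor, a higher number a weaker inhibitor), giving 507 nM. Compound 1 `Clc1ccc(C2=CC3CNCC(C2)C3)cn1` gives 6.2 nM in this assay and compound 2 `C1=C(c2cncc(Oc3ccccc3)c2)CC2CNCC1C2` gives 1.9 nM; both sit far lower than compound 3, and compound 2 is the furthest from it. Among the compounds with values here, the only measured step with one change is an 82-fold higher number from compound 1 to compound 3 (1.91 log units; beyond the scatter), a large rise.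

Compound 4 `C1=C(c2cccnc2)CC2CNCC1C2` differs from compound 3 by hydrogen in place of phenyl on an aromatic carbon, on an aromatic carbon of a six-membered aromatic ring with 1 nitrogen, next to the ring nitrogen, para to a group of 9 heavy atoms. Within the data shown here, this reverses the kind of change that raised the number from compound 1 to compound 3, though what enters is hydrogen rather than chloro; no measured pair shows hydrogen against chloro at that place, so that part is open. The expectation is a large drop, estimated as a 42-fold lower number from compound 3 to compound 4 (1.63 log units; beyond the scatter), landing near compound 1. Compound 4 is therefore expected to give about 12 nM in this assay, within 3 nM to 50 nM.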

Compound 4, inhibition constant: 12 nM
Beside the measured number, compound 4's estimate shows no gap at the digits printed; the measured number falls inside the stated range.
By their numbers in this assay, from the lowest: compound 2; then compounds 1 and 4 (each within the scatter of the next); then compound 3.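

Hydrogen at the aromatic carbon next to the ring nitrogen gives a baseline for the shared core in this assay (a 42-fold lower number from compound 3 to compound 4 (1.63 log units; beyond the scatter)), which ties the high number to the phenyl at this place. Hydrogen and chloro are not separated at this place (a 1.9-fold higher number from compound 1 to compound 4 (0.29 log units; within the scatter)). Phenoxy goes against any reading that an added aromatic ring on this core raises the number, since hydrogen in its place gives a rise (a 6.3-fold higher number from compound 2 to compound 4 (0.80 log units; beyond the scatter)), whereas hydrogen in place of phenyl gives a drop.

Nothing on hand accounts for the contrast between phenyl and phenoxy. From the compounds shown here alone, whether a methyl, a methoxy or an amine at this place would stay with hydrogen and chloro or move towards phenyl remains open.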